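The source may report more compounds than this note shows. Statements on the series, on what has been measured and on what is new or still open speak of the compounds shown alone.

Compound 1 `O=C(/C=C/c1ccc(CN2C(=O)/C(=C3\Nc4ccccc4\C3=N/O)c3cc(Cl)ccc32)cc1)NO`, compound 2 `COc1ccc2c(c1)/C(=C1/Nc3ccccc3/C1=N\O)C(=O)N2Cc1ccc(/C=C/C(=O)NO)cc1` and compound 3 `O=C(/C=C/c1ccc(CN2C(=O)/C(=C3\Nc4ccccc4\C3=N/O)c3cc(F)ccc32)cc1)NO` share one core and differ only in a single group on an aromatic carbon: chloro, methoxy and fluoro. In a functional assay on SW-620 cells (Homo sapiens) for cytotoxicity, read by colorimetric assay (a lower number here means a stronger inhibitor, a higher number a weaker inhibitor), compound 1 gives 80 nM, compound 2 gives 40 nM and compound 3 gives 50 nM. Compound 3 thus lies within the scatter of both other compounds, so the three cannot be ranked. Compound 4 `O=C(/C=C/c1ccc(CN2C(=O)/C(=C3\Nc4ccccc4\C3=N/O)c3ccccc32)cc1)NO` carries no such group: hydrogen in place of fluoro on an aromatic carbon. Within the data shown here, three measured steps bear on this: a 1.6-fold lower number from compound 1 to compound 3 (0.20 log units; within the scatter), a 2.0-fold lower number from compound 1 to compound 2 (0.30 log units; within the scatter) and a 1.3-fold higher number from compound 2 to compound 3 (0.10 log units; within the scatter). All three lie within the scatter, so exchanging this group has so far produced no measurable difference. Among the measured compounds shown here, no measured compound carries hydrogen at this place, so the exact change remains untested. No step beyond the scatter is expected in this assay, and no direction can be given. The expected step is a 1.2-fold higher number from compound 3 to compound 4 (0.08 log units; within the scatter). For compound 4 the estimated value is 60 nM, with an expected range from 25 nM to 140 nM.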

Compound 4, half-maximal inhibitory concentration: 50 nM
Beside the measured number, compound 4's estimate is 1.2-fold (0.08 log units) above it; the range from low to high includes it.
By their numbers in this assay, from the lowest: compounds 2, 3, 4 and 1 (each within the scatter of the next).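

Taking the group off altogether gives no change at the digits printed from compound 3 to compound 4 (within the scatter), and in this assay there is also a 1.3-fold higher number from compound 2 to compound 4 (0.10 log units; within the scatter) and a 1.6-fold lower number from compound 1 to compound 4 (0.20 log units; within the scatter) on the same change. The earlier compounds shown here compared only fluoro, methoxy and chloro with one another, whereas these steps add plain hydrogen on this aromatic carbon, and it cannot be told apart from any of the three groups. Among these four compounds, then, no group at this place is needed for a value in this range, and no available measurement explains this result.

From the compounds shown here alone, whether an amine, a carboxylic acid or a longer chain on this carbon would also stay within the scatter remains open. What these exchanges do outside this assay is open too.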